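Swapping the Sulfonyl Aryl Group of Compound 2

This account rests on a few compounds, and the source may have more. Where it says the series, first, only, none or still open, it means among the compounds named here.

Compound 1 `COc1ccc(-c2cc(=O)c3c(OC)cc(OC)cc3n2S(=O)(=O)c2ccc(F)cc2)cc1` was tested in a functional assay on HepG2 cells (Homo sapiens) for antiproliferative activity, with a stated time of 72 h; a lower number here means that less compound is needed, a higher number that more compound is needed for the effect; in that test compound 1 gives only a limit, > 65500 nM. Compound 2 `COc1ccc(-c2cc(=O)c3c(OC)cc(OC)cc3n2S(=O)(=O)c2ccc(C)cc2)cc1` likewise gives only a limit in this assay, namely > 44800 nM. The step that the two limits leave unreadable from compound 1 to compound 2 therefore cannot be read, and compound 2 stands at a limit rather than at a number. Compound 3 `COc1ccc(-c2cc(=O)c3c(OC)cc(OC)cc3n2S(=O)(=O)c2ccc(Br)s2)cc1` differs from compound 2 by 5-bromothiophen-2-yl in place of 4-methylphenyl on a sulfonyl sulfur. Within the data shown here, no measured step has a readable size, so there is no basis to expect a change beyond the scatter. The expected step that the limit leaves unreadable from compound 2 to compound 3 is accordingly small. Compound 3 is therefore estimated at 50000 nM, with a range from 8000 nM to 200000 nM.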

Compound 3, half-maximal effective concentration: > 48200 nM
Compound 3 was reported as a limit (the forecaster's own chance of this, stated with the estimate: 70%); the middle value is on the limit's open side.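

Compound 3, like compound 1 and compound 2, gives only a limit, so no step among these three compounds can be read. The compounds shown leave open whether changing the group on the sulfonyl sulfur alters the result in this assay.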